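Notes on replacing 4-fluorophenyl with 2-methyl-1,3-oxazol-4-yl

This account rests on a few compounds, and the source may have more. Where it says the series, first, only, none or still open, it means among the compounds named here.

Measured so far in a physicochemical assay for lipophilicity; a lower number here means a more polar compound, a higher number a more lipophilic compound:
- compound 1 `Cc1nc(-c2cc(C(F)(F)F)ccc2[C@H]2CCOc3cc(S(=O)(=O)Nc4ccncn4)ccc32)co1` with "not determined" (no result reported) as its entry
- compound 2 `Cc1nc(-c2cc(C(F)(F)F)ccc2[C@@H]2CCOc3cc(S(=O)(=O)Nc4nccs4)ccc32)co1` with 2.9 as its value
- compound 3 `O=S(=O)(Nc1nccs1)c1ccc2c(c1)OCC[C@@H]2c1ccc(C(F)(F)F)cc1-c1ccc(F)cc1` with 4.5 as its value

Compound 3 at 4.5 stands highest of the two numbers available in this assay. Compound 2 lies lower by a gap beyond the usual scatter, and compound 1 adds no number.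

The next compound is compound 4 `Cc1nc(-c2cc(C(F)(F)F)ccc2[C@H]2CCOc3cc(S(=O)(=O)Nc4nccs4)ccc32)co1`, reached from compound 3 by a single change: 2-methyl-1,3-oxazol-4-yl in place of 4-fluorophenyl on an aromatic carbon. The change sits on an aromatic carbon, ortho to a large group and meta to a trifluoromethyl group.

Among the measured compounds shown here, no step between measured compounds isolates this change, so its size cannot be read directly. The best guide is compound 2 at 2.9 in this assay, which carries the same 2-methyl-1,3-oxazol-4-yl as compound 4. A downward step beyond the scatter is therefore expected, close in size to the gap between the two measured values. The expected move is a number 1.60 log units lower from compound 3 to compound 4 (beyond the scatter) in this assay on this reasoning. For compound 4 2.9 is the estimate, with 2.6 to 3.2 as the expected range for the measurement.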

Compound 4, distribution coefficient: 2.9
Compound 4: middle estimate and measured number agree at the digits printed; low and high end bracket the measured number.
By their numbers in this assay, from the lowest: compounds 2 and 4 (each within the scatter of the next); then compound 3.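

In this assay, the swap at this position now has a direct reading: 2-methyl-1,3-oxazol-4-yl in place of 4-fluorophenyl, on an aromatic carbon ortho to a large group and meta to a trifluoromethyl group, gives a number 1.60 log units lower from compound 3 to compound 4 (beyond the scatter). Among the compounds shown here, the earlier compounds offered no step that isolated this change, so this is the first pair to fix its size at this position. The second step, no change at the digits printed from compound 2 to compound 4 (within the scatter), adds a separate finding: inverting the drawn stereocentre at the saturated ring carbon leaves the reading in this assay unchanged at the digits printed, and that step speaks to configuration alone: the fact that compounds 2 and 4 differ only in the configuration as drawn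

On these data alone, one replacement at this position gives a single step, so it remains open whether the size of that step carries over to other groups in the same place, such as a carboxylic acid or a primary amine. As far as these compounds go, it also remains open whether the same replacement would give a step of similar size with a different group on the sulfonamide nitrogen.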